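This account rests on a few compounds, and the source may have more. Where it says the series, first, only, none or still open, it means among the compounds named here.

Measured compounds:
Compound 1: `O=C(O)CCC(Cc1ccc(OCc2ccc3ccccc3n2)cc1)c1ccccc1` — 65 nM
Compound 2: `CCCC(CCC(=O)O)Cc1ccc(OCc2ccc3ccccc3n2)cc1` — 30 nM
Compound 3: `c1ccc(C(CCc2nnn[nH]2)Cc2cccc(OCc3ccc4ccccc4n3)c2)cc1` — 24 nM

All three were tested in a functional assay (lung) for inhibition, with Cavia porcellus as the target; on this read-out lower numbers stand for stronger inhibition and higher numbers for weaker inhibition. Compound 1 and compound 2 share one core and differ in a single spot: propyl in place of phenyl on a saturated chain carbon bound to two saturated chain carbons. This change gave a 2.2-fold lower number from compound 1 to compound 2 (0.34 log units; beyond the scatter), a modest gain in inhibition.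

Compound 3 is built on a different core; the difference between the two cores is not broken down here. In this assay compound 3 gives a number that sits within the scatter of compound 2, so the two cannot be told apart, while its gap to compound 1 lies beyond the scatter.

Compound 4, `CCCC(CCc1nnn[nH]1)Cc1cccc(OCc2ccc3ccccc3n2)c1`, has not yet been measured. It differs from compound 3 by propyl in place of phenyl on a saturated chain carbon bound to two saturated chain carbons. For the measured compounds named here, this is the same change, at the same place, as the one from compound 1 to compound 2. If it carries over, the expected step is a 1.8-fold lower number from compound 3 to compound 4 (0.27 log units; within the scatter), resting on the measured step of a 2.2-fold lower number from compound 1 to compound 2 (0.34 log units; beyond the scatter). Going by the values given here, the core of compound 3 is not the core of compound 1, and only one earlier example of the change exists. The expectation is held with a wide margin. Compound 4 is therefore estimated at 13 nM in this assay, expected to fall between 5 nM and 35 nM.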

Compound 4, half-maximal inhibitory concentration: 16 nM
The estimate for compound 4 lay 1.2-fold (0.09 log units) below the measured number; the range from low to high includes it.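

In this assay, putting propyl in place of phenyl on the core of compound 3 gave a 1.5-fold lower number from compound 3 to compound 4 (0.18 log units; within the scatter), so on this core alone the change cannot be told apart from the ordinary variation between repeated measurements. Set beside the first example of the same change, the result on the second core does not differ from it, and the two steps can be read as consistent: the same change on two cores in this assay, a 2.2-fold lower number (0.34 log units; beyond the scatter) from compound 1 to compound 2 and a 1.5-fold lower number (0.18 log units; within the scatter) from compound 3 to compound 4, 1.4-fold (0.16 log units) apart, within the scatter of two such steps

This shows that, on these two cores, the swap from phenyl to propyl did not cost inhibition beyond the scatter, but it does not show that the clear gain seen on the core of compound 1 is repeated on the core of compound 3, and two cores are too few to make a rule for the series.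

The compounds shown leave open how other groups would behave on a saturated chain carbon bound to two saturated chain carbons, since only phenyl and propyl appear there. A longer chain, a shorter chain such as ethyl, or an amine at that place could give a different number, and these examples offer no way of predicting it.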